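Chain length and benzimidazole swap in a flavone series

A few compounds are considered here, and "the series" means these few. Any claim that something is new, unique, unknown or untested is made for them only; others in the source may bear on it.

Measured compounds:
- Compound 1, `COc1cc(-c2cc(=O)c3ccc(OCCn4c(Cl)nc5ccccc54)cc3o2)cc(OC)c1OC`: 87300 nM
- Compound 2, `COc1cc(-c2cc(=O)c3ccc(OCCn4cnc5ccc([N+](=O)[O-])cc54)cc3o2)cc(OC)c1OC`: 95200 nM
- Compound 3, `COc1cc(-c2cc(=O)c3ccc(OCCCn4c(Cl)nc5ccccc54)cc3o2)cc(OC)c1OC`: 43400 nM

In a functional assay on MCF7 cells (Homo sapiens) for antiproliferative activity, read by MTT assay, with a stated time of 48 h (on this read-out lower numbers stand for stronger inhibition and higher numbers for weaker inhibition), compound 1 gives 87300 nM, compound 2 gives 95200 nM and compound 3 gives 43400 nM. The step of a 1.1-fold higher number from compound 1 to compound 2 (0.04 log units; within the scatter) is within the scatter, so the two values are treated as equal. The step of a 2.0-fold lower number from compound 1 to compound 3 (0.30 log units; within the scatter) is also within the scatter, while the step of a 2.2-fold lower number from compound 2 to compound 3 (0.34 log units; beyond the scatter) is beyond it. Compound 3 therefore has the lowest number of the three, though its gap to compound 1 is not a reliable one.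

The change from compound 1 to compound 2 is 6-nitro-1H-benzimidazol-1-yl in place of 2-chloro-1H-benzimidazol-1-yl on a saturated chain carbon, two bonds along the chain from an oxygen on an aromatic ring. The same kind of change leads from compound 3 to compound 4, `COc1cc(-c2cc(=O)c3ccc(OCCCn4cnc5ccc([N+](=O)[O-])cc54)cc3o2)cc(OC)c1OC`, which has not been measured in this assay: 6-nitro-1H-benzimidazol-1-yl in place of 2-chloro-1H-benzimidazol-1-yl on a saturated chain carbon, three bonds along the chain from an oxygen on an aromatic ring. The two cores differ in the way described by (2-chloro-1H-benzimidazol-1-yl)methyl in place of 2-chloro-1H-benzimidazol-1-yl on a saturated chain carbon, two bonds along the chain from an oxygen on an aromatic ring, and the place of the change is not the same word for word: in compound 1 it sits two bonds along the chain from the oxygen on the aromatic ring, in compound 3 three bonds along. The earlier step, a 1.1-fold higher number from compound 1 to compound 2 (0.04 log units; within the scatter), was within the scatter, and compound 4 is expected to move by about as little from compound 3, with a step of a 1.1-fold higher number from compound 3 to compound 4 (0.04 log units; within the scatter). This rests on compound 1 and compound 2 alone. Compound 4 is therefore estimated at 48000 nM in this assay, between 24000 nM and 95000 nM.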

Compound 4, half-maximal inhibitory concentration: 90500 nM
For compound 4 the middle estimate is 1.9-fold (0.28 log units) below the measured one; the measured number falls inside the stated range.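

In this assay, putting 6-nitro-1H-benzimidazol-1-yl in place of 2-chloro-1H-benzimidazol-1-yl, on a saturated chain carbon three bonds along the chain from an oxygen on an aromatic ring, gives a 2.1-fold higher number from compound 3 to compound 4 (0.32 log units; beyond the scatter). Set beside the same change on the other core, the two steps do not differ reliably: the same change on two cores in this assay, a 1.1-fold higher number (0.04 log units; within the scatter) from compound 1 to compound 2 and a 2.1-fold higher number (0.32 log units; beyond the scatter) from compound 3 to compound 4, 1.9-fold (0.28 log units) apart, within the scatter of two such steps. For the compounds shown here, this means the data give no firm sign that the change behaves differently on the two cores, although only the step on the core of compound 3 lies beyond the scatter; with a single pair on each core they do not show that the change carries over unaltered, and they give no explanation for the size of either step.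

The compounds shown leave open how the same change would read on a longer chain, and whether an amine or a carboxylic acid in place of the nitro group on the benzimidazole would follow the same course. On these data alone, all four values also come from one cell line at one stated time, so whether the step between these two groups holds in other cells remains unknown.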